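The source may hold more compounds than are shown below. What is called first, only, known or untested is meant among the compounds shown, and "the series" means these compounds.

Measured so far:
compound 1 `Cc1nn(C)c(Oc2cccc(F)c2)c1/C=N\CCCCCOc1cc2oc(=O)cc(C)c2cc1Cl`: 11800 nM
compound 2 `Cc1nn(C)c(Oc2ccc(Cl)cc2)c1/C=N\CCCCCOc1cc2oc(=O)cc(C)c2cc1Cl`: 17500 nM
compound 3 `Cc1nn(C)c(Oc2cccc(F)c2F)c1/C=N\CCCCCCOc1cc2oc(=O)cc(C)c2cc1Cl`: 22800 nM

All three numbers come from a functional assay on SMMC-7721 cells (Homo sapiens) for antiproliferative activity, read by MTT assay, with a stated time of 72 h; on this read-out lower numbers stand for stronger inhibition and higher numbers for weaker inhibition. Compound 3 cannot be set apart from the others: its gaps to compound 2 and to compound 1 are both within the usual scatter of this assay, so the three compounds behave alike on what is shown.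

Compound 4 `Cc1nn(C)c(Oc2cccc(Br)c2)c1/C=N\CCCCCCOc1cc2oc(=O)cc(C)c2cc1Cl` differs from compound 3 only in the ring at the end of the chain: 3-bromophenyl in place of 2,3-difluorophenyl on an oxygen on an aromatic ring. Among the measured compounds shown here, the one measured step that bears on such a swap of the halogen pattern on that ring is a 1.5-fold higher number from compound 1 to compound 2 (0.17 log units; within the scatter), which stayed within the scatter. The expectation for compound 4 is therefore a step of about a 1.1-fold lower number from compound 3 to compound 4 (0.06 log units; within the scatter), that is, none beyond the scatter, and an estimated value of 20000 nM with a range from 8000 nM to 50000 nM.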

Compound 4, half-maximal inhibitory concentration: 5080 nM
Estimate against measurement, compound 4: 3.9-fold (0.60 log units) above; the whole stated range lies above it.
By their numbers in this assay, from the lowest: compound 4; then compounds 1, 2 and 3 (each within the scatter of the next).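

Among the compounds shown here, replacing 2,3-difluorophenyl with 3-bromophenyl on the oxygen gives a 4.5-fold lower number from compound 3 to compound 4 (0.65 log units; beyond the scatter) and is the only step here that goes beyond the scatter. The halogens on this ring can therefore change the result, which the step between compound 1 and compound 2 did not show. Nothing available here explains this difference.

Going by these compounds, this single swap removes both fluorines and adds a bromine, so their separate contributions remain open. It is also unclear whether unsubstituted phenyl or 3-chlorophenyl on this chain would resemble compound 3 or compound 4.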